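Thiophen-2-yl in place of methyl: working notes

The source may hold more compounds than are shown below. What is called first, only, known or untested is meant among the compounds shown, and "the series" means these compounds.

Going by the values given here, compound 1 `Cc1ccc(S(=O)(=O)Oc2ccccc2/C=C(\C#N)C(=O)Nc2nnc(C)s2)cc1` and compound 2 `Cc1ccc(S(=O)(=O)Oc2cccc(/C=C(\C#N)C(=O)Nc3nnc(C)s3)c2)cc1` are the only compounds read so far in an ADME assay on HEK-293T cells (Homo sapiens) for inhibition, read by CCK-8 assay, with a stated time of 48 h; a higher number here means a weaker inhibitor, a lower number a stronger inhibitor. Compound 1 gives > 20000 nM as a limit and not a number. Compound 2 gives > 50000 nM as a limit too. Among the compounds with values here, compound 2 therefore has no number of its own, and the series offers no measured step to work from. Compound 3 `Cc1ccc(S(=O)(=O)Oc2cccc(/C=C(\C#N)C(=O)Nc3nnc(-c4cccs4)s3)c2)cc1` differs from compound 2 by thiophen-2-yl in place of methyl on an aromatic carbon and keeps the rest of the structure. Without a measured step, only a modest shift toward stronger inhibition in this assay is expected, perhaps none beyond the scatter, and another limit is quite possible. The estimated change an at least 1.2-fold lower number from compound 2 to compound 3 (0.09 log units; that floor lies within the scatter) is expected to be small. For compound 3 the estimated value is 40000 nM with 10000 nM to 100000 nM as the expected range.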

Compound 3, half-maximal inhibitory concentration: > 20000 nM
Compound 3 ended at the assay's limit; the forecaster's own chance of this, stated with the estimate: 60%; the middle value is on the limit's open side.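

Compound 2 and compound 3 both stand as limits and not numbers in this assay, and no step can be read between them. The compounds shown leave open whether thiophen-2-yl in place of methyl on an aromatic carbon changes inhibition at all, in either direction.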